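Lengthening the side chain of a naphthol lipoxygenase inhibitor

A few compounds are considered here, and "the series" means these few. Any claim that something is new, unique, unknown or untested is made for them only; others in the source may bear on it.

Measured compounds:
compound 1 `Cc1ccc2ccccc2c1O`, 130 nM
compound 2 `COc1ccc2ccc(Cc3ccccc3)c(O)c2c1`, 3500 nM

In an assay on RBL-1 cells with Polyunsaturated fatty acid 5-lipoxygenase (Rattus norvegicus) as the target (a lower number here means a stronger inhibitor, a higher number a weaker inhibitor), compound 1 gives the lowest number of the two, and compound 2 gives a number far higher, well beyond the usual scatter. Compound 3 `O=C(O)CCCCc1ccc2ccccc2c1O` is not yet measured. It differs from compound 1 by 3-carboxypropyl in place of hydrogen on a saturated chain carbon bound to an aromatic carbon. Among the measured compounds shown here, no measured pair shows this change, so the expected step in this assay rests on judgment alone: a modest move toward a weaker inhibitor, of a size that may only just exceed the scatter, is expected as a 3.1-fold higher number from compound 1 to compound 3 (0.49 log units; beyond the scatter). Compound 3 is therefore estimated at 400 nM, within the range 80 nM to 2000 nM.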

Compound 3, half-maximal inhibitory concentration: 4200 nM
The estimate for compound 3 lay 11-fold (1.02 log units) below the measured number; measured number above the stated range.
By their numbers in this assay, from the lowest: compound 1; then compounds 2 and 3 (each within the scatter of the next).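

With a 32-fold higher number from compound 1 to compound 3 (1.51 log units; beyond the scatter) in this assay, 3-carboxypropyl in place of hydrogen on a saturated chain carbon bound to an aromatic carbon brings a large loss, so this position does not accept this chain without penalty. The earlier compounds shown here offered no pair that tested this place. Nothing at hand explains the loss.

Whether the loss follows the chain or its terminal carboxylic acid remains open, since a plain butyl chain, a methyl ester or an amine at the chain end is absent from the compounds shown. A shorter acid chain is equally absent.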